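Aryl change on the saturated ring carbon: outlook for compound 3

The compounds below may be only part of what the source reports. "The series", "measured", "known", "first", "only" and "open" are said of these compounds alone.

Measured so far:
compound 1 `Cc1cccc(NC(=O)CN2CCC(c3cccc(F)c3)CC2)c1` — 512 nM
compound 2 `Cc1cccc(NC(=O)CN2CCC(c3ccc(O)cn3)CC2)c1` — 3.8 nM

Going by the values given here, in a functional assay on HEK293 cells for agonist activity at D(4) dopamine receptor (Homo sapiens), read by FLIPR (on this read-out lower numbers stand for an effect already at smaller amounts and higher numbers for an effect only at larger amounts of compound), compound 2 holds the lowest of the two numbers; its only neighbour is compound 1, separated by the step of a 130-fold lower number from compound 1 to compound 2 (2.13 log units; beyond the scatter). Compound 3 `Cc1cccc(NC(=O)CN2CCC(c3ccccc3C#N)CC2)c1` is not yet measured. The change is 2-cyanophenyl in place of 5-hydroxypyridin-2-yl on a saturated ring carbon. Among the compounds with values here, the one step on record bears on it in reverse: it shows that the 5-hydroxypyridin-2-yl group, not the core, carries the low number of compound 2, and compound 3 returns to a carbon-only ring, as in compound 1. A large rise is therefore expected, a 39-fold higher number from compound 2 to compound 3 (1.60 log units; beyond the scatter). For compound 3 the estimate in this assay is 150 nM, with a range from 20 nM to 1500 nM.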

Compound 3, half-maximal effective concentration: 8 nM
Compound 3: the middle estimate sits 19-fold (1.27 log units) above what was measured; measured number below the stated range.
By their numbers in this assay, from the lowest: compound 2; then compound 3; then compound 1.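

A carbon-only aryl ring on this saturated ring carbon can still give a low number in this assay, with a 64-fold lower number from compound 1 to compound 3 (1.81 log units; beyond the scatter). With a 2.1-fold higher number from compound 2 to compound 3 (0.32 log units; beyond the scatter), most of the gain stays without the ring nitrogen or hydrogen-bond donor of the 5-hydroxypyridin-2-yl group, so neither is required here. Compound 1 also lacks a donor yet has a much higher number, so donor count alone does not sort these compounds.

Going by these compounds, whether the nitrile itself carries the low number stays open, as does the outcome with an amine or a carboxylic acid in its place. No measured evidence on the cause of these steps is at hand.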